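This account rests on a few compounds, and the source may have more. Where it says the series, first, only, none or still open, it means among the compounds named here.

Measured compounds:
- compound 1, `COc1cc(Cl)cc(-c2nn(-c3cccc(NC(=O)c4ccc(Cl)c(Cl)c4)c3)cc2-c2ccncc2)c1`: 59.2% in a functional assay on CCRF-CEM cells (Homo sapiens) for inhibition, read by sulforhodamine B assay, with a stated time of 48 h, tested at 10 uM; a higher number here means a weaker effect of the compound at the concentration tested, a lower number a stronger effect
- compound 2, `COc1cc(Cl)cc(-c2nn(-c3cccc(NC(=O)Nc4cc(C(F)(F)F)cc(C(F)(F)F)c4)c3)cc2-c2ccncc2)c1`: -22%

Compound 1 stands highest of these two numbers, with compound 2 far lower, a gap beyond the scatter; the two differ in more than one place, so nothing further can be read from that pair. Compound 3, `COc1cc(Cl)cc(-c2nn(-c3cccc(NC(=O)c4cccc(C(F)(F)F)c4)c3)cc2-c2ccncc2)c1`, has not yet been measured. It differs from compound 1 in one place: 3-(trifluoromethyl)phenyl in place of 3,4-dichlorophenyl on a carbonyl carbon. Going by the values given here, with no comparable single-point step among the measured compounds, only a small step is expected, from compound 1 to compound 3 of a number 7.2 percentage points lower from compound 1 to compound 3 (within the scatter), which is within the scatter. Compound 3 is therefore estimated at 52%, between 20% and 85%.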

Compound 3, a percentage reported as activity, at one concentration (the size of the read-out at that concentration, not a potency): 42.3%
Estimate against measurement, compound 3: 9.7 percentage points above; the measured number falls inside the stated range.
By their numbers in this assay, from the lowest: compound 2; then compound 3; then compound 1.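

In this assay putting 3-(trifluoromethyl)phenyl in place of 3,4-dichlorophenyl on a carbonyl carbon gives a number 16.9 percentage points lower from compound 1 to compound 3 (beyond the scatter) and so a stronger effect at the concentration tested. Going by these compounds alone, this is the first single change that can be read here, and it shows that the aromatic group at this position can alter the read-out, though only modestly. Nothing available explains why the number moves. Still open, on these data alone, is how a cyclohexyl ring or a simple methyl group on this carbonyl carbon would read.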